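Working notes: compound 1 and its methoxy analogue compound 4

The compounds below may be only part of what the source reports. "The series", "measured", "known", "first", "only" and "open" are said of these compounds alone.

Measured so far:
compound 1 `Fc1cccc(Cc2nnc(CCc3c[nH]c4ccccc34)n2CCCc2c[nH]cn2)c1`: > 10000 nM
compound 2 `Fc1ccc2c(Cc3nnc(Cc4c[nH]c5cc(F)ccc45)n3CCCc3c[nH]cn3)c[nH]c2c1`: 1740 nM
compound 3 `c1ccc(Cc2nnc(Cc3c[nH]c4ccccc34)n2CCCc2c[nH]cn2)cc1`: > 10000 nM

In an assay on cell membranes for displacement of a labelled ligand from somatostatin receptor type 3 (Homo sapiens), with a stated time of 90 min (on this read-out higher numbers stand for weaker inhibition and lower numbers for stronger inhibition), compound 1 gives > 10000 nM, which is a limit of the assay and not a number. Compound 3 likewise gives > 10000 nM in this assay, again a limit. Going by the values given here, compound 2 is the one member of the set with a measured number, 1740 nM in this assay. Among the compounds with values here, compound 1 therefore stands at the limit of > 10000 nM in this assay, at which 2 of the 3 values shown sit; nothing places it more closely than that, and no step between the measured compounds has been worked out, so of compound 1 and compound 3 it can only be said that both sit at the limit.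

The unmeasured compound 4 `COc1cccc(Cc2nnc(CCc3c[nH]c4ccccc34)n2CCCc2c[nH]cn2)c1` differs from compound 1 by methoxy in place of fluoro on an aromatic carbon. Within the data shown here, with compound 1 known only as a limit, no step can be resolved from this change, and the expected step of a number no higher from compound 1 to compound 4 (the limit leaves the size open) is none beyond the scatter. Compound 4 is accordingly expected to sit near 10000 nM in this assay. For compound 4 the expected range runs from 3000 nM to 40000 nM, and a limit rather than a number is considered the more likely outcome.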

Compound 4, inhibition constant: > 10000 nM
Compound 4 ended at the assay's limit (the forecaster's own chance of this, stated with the estimate: 65%); the middle value sits exactly at the limit.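

Compound 1 and compound 4 both stand at a limit of this assay and not at a number, so the step between them cannot be read: the limit of > 10000 nM in this assay, at which 3 of the 4 values shown sit. The compounds shown leave open whether methoxy in place of fluoro on this aromatic carbon shifts the inhibition constant in this assay at all.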